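Ortho-Hydroxy on a Phenyl Ring across Two Cores

The source may report more compounds than this note shows. Statements on the series, on what has been measured and on what is new or still open speak of the compounds shown alone.

The study compares four compounds in a functional assay on PA-1 cells (Homo sapiens) for cytotoxicity, read by MTT assay, with stated times of 6 h and 48 h; a higher number here means a weaker inhibitor, a lower number a stronger inhibitor. Compound 1 `O=C(/C=C/c1cc(Br)c(Br)[nH]1)c1ccccc1O` and compound 2 `O=C(/C=C/c1cc(Br)c(Br)[nH]1)c1ccccc1` share a core; compound 3 `Cn1c(-c2cc(-c3ccccc3)no2)cc(Br)c1Br` and the not yet measured compound 4 `Cn1c(-c2cc(-c3ccccc3O)no2)cc(Br)c1Br` share another. How the core of compound 2 and the core of compound 3 differ is not broken down here.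

In this assay compound 1 gives 330 nM. For compound 2 only a limit is known, >= 100000 nM. The change between them is hydroxy in place of hydrogen on an aromatic carbon. The step it produced, an at least 300-fold lower number from compound 2 to compound 1 (2.48 log units; beyond the scatter), rests partly on (the limit of >= 100000 nM in this assay, at which 2 of the 3 values shown sit), so its true size may be larger than the number says.

For compound 3 only a limit is known as well, >= 100000 nM. Compound 4 carries the same change on its own core, (hydroxy in place of hydrogen on an aromatic carbon); the place is described in the same words for both pairs. Within the data shown here, because the one measured instance, an at least 300-fold lower number from compound 2 to compound 1 (2.48 log units; beyond the scatter), was large, a lowering is expected for compound 4 too, though the core of compound 3 differs from that of compound 2 and nothing shows that the change carries over unchanged. The step expected from compound 3 to compound 4 is therefore an at least 10-fold lower number from compound 3 to compound 4 (1.00 log units; beyond the scatter), smaller than the measured one. Compound 4 is expected to give about 10000 nM in this assay, within a wide range from 500 nM to 100000 nM.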

Compound 4, half-maximal inhibitory concentration: >= 100000 nM
Compound 4: a limit, no number; the forecaster's own chance of this, stated with the estimate: 40%; middle value at least 10-fold (1.00 log units) from the limit.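

In this assay, compound 3 and compound 4 each give only a limit, and no step can be read from compound 3 to compound 4 because both sit at the same limit: the limit of >= 100000 nM in this assay, at which 3 of the 4 values shown sit. The compounds shown leave open whether hydroxy in place of hydrogen on an aromatic carbon changes the number at all on the core of compound 3, and if so, by how much.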